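The compounds below may be only part of what the source reports. "The series", "measured", "known", "first", "only" and "open" are said of these compounds alone.

Of the compounds shown here, three have so far been tested in a functional assay on the whole organism for inhibition, with Mus musculus as the target, with a stated time of 3 h, at a dose of 50 mg/kg by the oral route; a lower number here means less inhibition, a higher number more inhibition at the dose given (going by the name of the read-out). Compound 1 `Cc1ccc(-c2c(S(=O)(=O)c3ccccc3)cnc3cc(C)nn23)cc1` gives 23.2%, and compound 2 `O=S(=O)(c1ccccc1)c1cnc2cc(-c3ccc(Cl)cc3)nn2c1-c1ccc(Br)cc1` gives 24.8%. Compound 3 `Cc1ccc(-c2c(S(=O)(=O)c3ccccc3)cnc3ncnn23)cc1` gives 4.4%, the lowest of the three; its gaps to compound 1 and to compound 2 both lie beyond the usual scatter of this kind of measurement. The next compound to be measured is compound 4 `O=S(=O)(c1ccccc1)c1cnc2ncnn2c1-c1ccc(Br)cc1`, which differs from compound 3 in a single place: bromo in place of methyl on an aromatic carbon. Among the measured compounds shown here, no pair of measured compounds shows this same change on an otherwise unchanged structure, so its effect on inhibition cannot be read from the data at hand. The expected change is a number 3.6 percentage points higher from compound 3 to compound 4 (within the scatter), which would stay within the usual scatter. Compound 4 is therefore estimated to give 8%, within a range from 0% to 22%.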

Compound 4, a percentage reported as inhibition, in the whole organism at one dose (the size of the read-out at that dose, not a potency): 1.6%
For compound 4 the middle estimate is 6.4 percentage points above the measured one; low and high end bracket the measured number.
By their numbers in this assay, from the lowest: compounds 4 and 3 (each within the scatter of the next); then compounds 1 and 2 (each within the scatter of the next).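

Bromo in place of methyl on this aromatic carbon is the first single-place change available in this assay, and it gives a number 2.8 percentage points lower from compound 3 to compound 4 (within the scatter). On this core, then, the step from 4-methylphenyl to 4-bromophenyl does not separate the two compounds at the dose given. No measurement at hand bears on why this is so. From the compounds shown here alone, whether an amine or a carboxylic acid at this same place would shift inhibition remains open. So does whether the same swap would give a similar step on the core of compound 1.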